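Aryl for Cyclohexyl on the Core: Acid Dissociation Expected Steady

The compounds below may be only part of what the source reports. "The series", "measured", "known", "first", "only" and "open" are said of these compounds alone.

Compound 2 `COc1ccc(F)cc1CNCCCNc1ccnc2cc(C3CCCCC3)ccc12` gives 9.47 in a physicochemical assay for acid dissociation. Compound 1 `COc1cccc(CNCCCNc2ccnc3cc(C4CCCCC4)ccc23)c1O` gives 9.47 and compound 3 `CC(C)CCc1ccc2c(NCCCNCc3ccco3)ccnc2c1` gives 9.47 in this assay, so compound 2 stands level with both at the digits shown. Among the measured compounds shown here, the only step between measured compounds that differ in one place, no change at the digits printed from compound 1 to compound 2 (within the scatter), swapped the group on the saturated chain carbon bound to an amine nitrogen without change beyond the scatter. Compound 4 `COc1ccc(F)cc1CNCCCNc1ccnc2cc(-c3ccc(C(C)(C)C)cc3)ccc12` differs from compound 2 by 4-(tert-butyl)phenyl in place of cyclohexyl on an aromatic carbon. For the measured compounds named here, no measured step alters the group on the shared core, so the expectation rests on the steadiness seen so far. The step of no change at the digits printed from compound 2 to compound 4 (within the scatter) is expected to stay within the scatter. Compound 4 is therefore estimated at 9.47 in this assay, with a range from 9.17 to 9.77.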

Compound 4, acid dissociation constant: 9.47
Estimate against measurement, compound 4: no gap at the digits printed, and the stated range covers the measured number.
By their numbers in this assay, from the lowest: compounds 1, 2, 3 and 4 (each within the scatter of the next).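

Among the compounds shown here, the exchange of cyclohexyl for 4-(tert-butyl)phenyl on an aromatic carbon of the shared core gives the only measured step at this position, and in this assay it reads no change at the digits printed from compound 2 to compound 4 (within the scatter). Here a six-membered non-aromatic ring of carbon gives way to a larger substituent with a six-membered aromatic ring, and the read-out stays within the scatter. Nothing at hand accounts for this steadiness. Still open, on these data alone, is whether an amine or a carboxylic acid on this aromatic carbon would leave the read-out equally steady.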